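The compounds below may be only part of what the source reports. "The series", "measured", "known", "first", "only" and "open" are said of these compounds alone.

Among the measured compounds shown here, compound 2, `COc1ccc2ccccc2c1C1C(C#N)=C(N)N(c2ccc(S(N)(=O)=O)cc2)C2=C1C(=O)CCC2`, is one of two compounds measured in a functional assay on Ehrlich cells (Mus musculus) for antiproliferative activity, read by trypan blue exclusion, with a stated time of 2 h, tested at 10 ug/mL; on this read-out lower numbers stand for a weaker effect and higher numbers for a stronger effect at the one concentration tested; there compound 2 gives 40%. Compound 1, `N#CC1=C(N)N(c2ccc(S(N)(=O)=O)cc2)C2=C(C(=O)CCC2)C1c1ccccc1`, shares the core and gives 10% in this assay. For the measured compounds named here, the one measured step, a number 30 percentage points higher from compound 1 to compound 2 (beyond the scatter), arose from putting 2-methoxynaphthalen-1-yl in place of phenyl on a saturated ring carbon, and compound 2 stands highest of the two numbers, with compound 1 as its nearest neighbour lying beyond the scatter below it.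

Compound 3, `Cc1ccoc1C1C(C#N)=C(N)N(c2ccc(S(N)(=O)=O)cc2)C2=C1C(=O)CCC2`, differs from compound 2 in the same place: 3-methylfuran-2-yl in place of 2-methoxynaphthalen-1-yl on a saturated ring carbon. Going by the values given here, the step of a number 30 percentage points higher from compound 1 to compound 2 (beyond the scatter) is the only measured change at that saturated ring carbon, and it shows that the group there matters, a modest gain having come with the larger 2-methoxynaphthalen-1-yl. The 3-methylfuran-2-yl of compound 3 is a smaller group, so the number is expected to move back toward the level of compound 1, a step of a number 20 percentage points lower from compound 2 to compound 3 (beyond the scatter) from compound 2 to compound 3. Compound 3 is therefore estimated to give 20% in this assay, within a range of 5% to 40%.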

Compound 3, a percentage reported as activity, at one concentration (the size of the read-out at that concentration, not a potency): 2%
For compound 3 the middle estimate is 18 percentage points above the measured one; measured number below the stated range.
By their numbers in this assay, from the lowest: compounds 3 and 1 (each within the scatter of the next); then compound 2.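

Going from 2-methoxynaphthalen-1-yl, with 12 heavy atoms, to 3-methylfuran-2-yl, with 6, gave a number 38 percentage points lower from compound 2 to compound 3 (beyond the scatter) in this assay and so removed the whole of the earlier gain at this saturated ring carbon. Exchanging phenyl for the five-membered aromatic ring of 3-methylfuran-2-yl gave a number 8 percentage points lower from compound 1 to compound 3 (within the scatter) in this assay so these two groups cannot be told apart on this read-out, and among the three compounds only the 2-methoxynaphthalen-1-yl of compound 2 stands out. No measurement shown here accounts for this difference.

The compounds shown leave open whether the gain in compound 2 needs both the two fused aromatic rings and the methoxy group, since a plain naphthalen-1-yl or a 2-methoxyphenyl at this carbon would separate the two. They also leave open how this position responds to groups of another kind, such as a dimethylaminophenyl or a carboxyphenyl, and whether any number here would hold at a concentration other than the single one tested.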